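A few compounds are considered here, and "the series" means these few. Any claim that something is new, unique, unknown or untested is made for them only; others in the source may bear on it.

In an ADME assay on J774 cells (Mus musculus) for cytotoxicity, read by fluorescence and resazurin assay, with a stated time of 24 h (on this read-out higher numbers stand for lower toxicity in this test and lower numbers for higher toxicity in this test), three compounds have been measured so far. Compound 1 `O=[N+]([O-])c1ccc(S(=O)(=O)Nc2cnccn2)cc1` gives >= 300000 nM, which is a limit of the assay and not a number. Compound 2 `O=[N+]([O-])c1ccc(S(=O)(=O)Nc2nccc3ccccc23)cc1` gives 41300 nM, and compound 3 `Cc1cc2cc(NS(=O)(=O)c3ccc([N+](=O)[O-])cc3)ccc2[nH]1` gives 132000 nM. Compound 3 therefore holds the higher of the two true numbers, and its gap to compound 2 lies beyond the scatter.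

The next compound, compound 4 `Cc1cc2cc(NS(=O)(=O)c3ccc(F)cc3)ccc2[nH]1`, keeps the rest of compound 3 and changes one group, fluoro in place of nitro on an aromatic carbon. The group sits on a six-membered aromatic ring of carbon only, para to a large group. Within the data shown here, no measured pair isolates this change, so the expectation rests on the three values and on the structures alone. In this assay, no step beyond the scatter is expected, and any movement is more likely upward than downward, because compound 3 at 132000 nM already sits high among the numbers seen. The expected step of a 1.1-fold higher number from compound 3 to compound 4 (0.06 log units; within the scatter) is therefore small. For compound 4 the estimated value is 150000 nM, with an expected range from 60000 nM to 300000 nM.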

Compound 4, half-maximal cytotoxic concentration: 40400 nM
Compound 4: middle estimate off by 3.7-fold (0.57 log units), on the high side, outside the stated range (below it).
By their numbers in this assay, from the lowest: compounds 4 and 2 (each within the scatter of the next); then compound 3. At a limit, above all of these: compound 1.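

In this assay, among these compounds, the change of nitro to fluoro on the six-membered aromatic ring of carbon only, para to a large group, gives the first step that can be read from a single change: a 3.3-fold lower number from compound 3 to compound 4 (0.51 log units; beyond the scatter), which is modest but beyond the scatter. This shows that the group at this place is not neutral on the shared core: with fluoro the read-out moves toward higher toxicity in this test, and with nitro it stands toward lower toxicity in this test. The single pair does not separate what leaving nitro contributes from what entering fluoro contributes, and nothing shown gives a cause for the step.

Going by these compounds, it remains open whether a chloro, a methoxy or an amine at the same place would land nearer compound 3 or compound 4, and where a plain hydrogen there would stand. On these data alone, it is also open whether the same change of nitro to fluoro would give a step of like size on the core of compound 2 or on the core of compound 1.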